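The compounds below may be only part of what the source reports. "The series", "measured", "known", "first", "only" and "open" are said of these compounds alone.

The measured compounds:
compound 1, `COc1ccc(-c2nc(N3CCNCC3)nc3ccccc23)c(OC)c1`: 50 ug/mL
compound 2, `c1ccc2c(c1)ccn2-c1nc(N2CCNCC2)nc2ccccc12`: 8.9 ug/mL
compound 3, `Cn1cc(-c2nc(N3CCNCC3)nc3ccccc23)c2ccccc21`: 50 ug/mL

All three share one core and were tested in an ADME assay on Vero cells (Chlorocebus sabaeus) for antiproliferative activity, read by MTT assay; a lower number here means a stronger inhibitor, a higher number a weaker inhibitor. Compound 1 gives 50 ug/mL in this assay, level at the digits shown with compound 3, and together these two carry the highest numbers of the three; their difference lies within the usual scatter, so no order between them can be read. Compound 2 is the furthest from compound 1: compound 2 gives 8.9 ug/mL, a lower number, and that gap lies beyond the scatter.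

The next compound is compound 4, `COc1cc(OC)c(-c2nc(N3CCNCC3)nc3ccccc23)c(OC)c1`, which has not yet been measured in this assay. It differs from compound 1 in one place: methoxy in place of hydrogen on an aromatic carbon. The new group enters on the six-membered aromatic ring of carbon only, ortho to a large group and meta to two methoxy groups, so compound 4 carries three methoxy groups on that ring where compound 1 carries two.

Within the data shown here, no measured pair in this set shows a step of exactly this kind, so the expectation rests on compound 1 alone. The step of no change at the digits printed from compound 1 to compound 4 (within the scatter) is expected to be small, with no change beyond the scatter in either direction. Compound 4 is therefore estimated at 50 ug/mL, with a range from 25 ug/mL to 100 ug/mL.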

Compound 4, half-maximal inhibitory concentration: 50 ug/mL
Compound 4: middle estimate and measured number agree at the digits printed, and the stated range covers the measured number.
By their numbers in this assay, from the lowest: compound 2; then compounds 1, 3 and 4 (each within the scatter of the next).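

Among these compounds, the first direct look at this change in this assay shows no change at the digits printed from compound 1 to compound 4 (within the scatter) when methoxy takes the place of hydrogen on an aromatic carbon. At this place on the six-membered aromatic ring, ortho to a large group and meta to two methoxy groups, the ring can therefore carry a third methoxy group with no readable shift in the number, something compound 1 alone could not show. No measurement here bears on why the number holds steady, so the result records an outcome and offers no explanation.

The compounds shown leave open what a different group at this same place would do, such as an amine, a carboxylic acid, or a longer chain like butoxy, since methoxy is the only group seen there and a single step cannot show how far this tolerance reaches. They also do not tell whether methoxy would behave the same way at other places on this ring, or whether taking away one of the two methoxy groups of compound 1 would move the number beyond the usual scatter.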